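This account rests on a few compounds, and the source may have more. Where it says the series, first, only, none or still open, it means among the compounds named here.

Measured compounds:
compound 1 `COc1cc2c(Nc3nc4ccc(C(=O)Nc5c(C)cccc5C)cc4s3)ncnc2cc1OCCCN1CCCCC1`
compound 2 `COc1cc2c(Nc3nc4ccc(C(=O)Nc5c(C)cccc5C)cc4s3)ncnc2cc1OCCCN1CCCCC1C`

In a functional assay on NCI-H661 cells (Homo sapiens) for cytotoxicity, read by WST assay, with a stated time of 72 h (a lower number here means a stronger inhibitor, a higher number a weaker inhibitor), compound 1 reaches only the limit > 100000 nM, not a number. In this assay, among the compounds with values here, compound 2 gives 84400 nM, the only number known here; the step of an at least 1.1-fold lower number from compound 1 to compound 2 (0.07 log units; that floor lies within the scatter) runs from a limit, since the limit of > 100000 nM in this assay, at which 1 of the 2 values shown sits, caps one of the two values. Compound 3 `COc1cc2c(Nc3nc4ccc(C(=O)Nc5c(C)cccc5C)cc4s3)ncnc2cc1OCCCN1CCC(C)CC1` carries the change (4-methylpiperidin-1-yl in place of 2-methylpiperidin-1-yl on a saturated chain carbon, three bonds along the chain from an oxygen on an aromatic ring). Only an at least 1.1-fold lower number from compound 1 to compound 2 (0.07 log units; that floor lies within the scatter) bears on it, and that step lies within the scatter, so for compound 3 no shift beyond the scatter is expected, with a 1.0-fold higher number from compound 2 to compound 3 (0.00 log units; within the scatter) as the estimated step. Compound 3 is estimated at 85000 nM, between 40000 nM and 180000 nM.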

Compound 3, half-maximal inhibitory concentration: 72300 nM
Estimate against measurement, compound 3: 1.2-fold (0.07 log units) above; the measured number falls inside the stated range.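

Moving the methyl from the 2-methylpiperidin-1-yl to the 4-methylpiperidin-1-yl group gives a 1.2-fold lower number from compound 2 to compound 3 (0.07 log units; within the scatter) in this assay, so the place of the methyl on this ring makes no difference that can be read here. The other step, an at least 1.3-fold lower number from compound 1 to compound 3 (0.14 log units; that floor lies within the scatter), also gives only a floor. It starts from a limit, not a number, so the size of the step from the unsubstituted ring remains unknown: the limit of > 100000 nM in this assay, at which 1 of the 3 values shown sits.

As far as these compounds go, whether 3-methylpiperidin-1-yl, morpholine or an open-chain diethylamino group on the same propyl chain would shift the number beyond the scatter stays open.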